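The compounds below may be only part of what the source reports. "The series", "measured", "known", "first", "only" and "open" are said of these compounds alone.

Measured compounds:
compound 1 `O=C1/C(=C/c2ccccc2F)CN(S(=O)(=O)c2ccc(F)cc2)C/C1=C\c1ccccc1F` – 7220 nM
compound 2 `CC(=O)Nc1ccc(S(=O)(=O)N2C/C(=C\c3ccccc3F)C(=O)/C(=C/c3ccccc3F)C2)cc1` – 5840 nM

In a functional assay on HepG2 cells (Homo sapiens) for cytotoxicity, read by MTT assay, with a stated time of 24 h (on this read-out lower numbers stand for stronger inhibition and higher numbers for weaker inhibition), compound 2 holds the lowest of the two numbers, but its nearest neighbour compound 1 sits within the scatter, as the step of a 1.2-fold lower number from compound 1 to compound 2 (0.09 log units; within the scatter) shows; the two values cannot be ordered.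

Compound 3 `COc1cc(/C=C2\CN(S(=O)(=O)c3ccc(NC(C)=O)cc3)C/C(=C\c3ccccc3F)C2=O)cc(OC)c1` is the next compound to measure. It differs from compound 2 by 3,5-dimethoxyphenyl in place of 2-fluorophenyl on a double-bonded chain carbon bound to a double-bonded ring carbon.

For the measured compounds named here, the only measured step, a 1.2-fold lower number from compound 1 to compound 2 (0.09 log units; within the scatter), concerns an aromatic carbon on a different part of the shared core and says nothing about exchange of the aryl group on the double-bonded chain carbon. Going by the values given here, no measured step bears on this change. With nothing to support a shift, the expectation for compound 3 is a step of a 1.0-fold higher number from compound 2 to compound 3 (0.01 log units; within the scatter) that stays within the scatter, with a wide range in both directions.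

Compound 3 is thus estimated at 6000 nM in this assay, with a range from 2500 nM to 15000 nM.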

Compound 3, half-maximal inhibitory concentration: 6800 nM
Compound 3: middle estimate off by 1.1-fold (0.05 log units), on the low side, within the range that was stated.
By their numbers in this assay, from the lowest: compounds 2, 3 and 1 (each within the scatter of the next).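

In this assay, for the compounds shown here, the exchange of 2-fluorophenyl for 3,5-dimethoxyphenyl on a double-bonded chain carbon bound to a double-bonded ring carbon gives a 1.2-fold higher number from compound 2 to compound 3 (0.07 log units; within the scatter), the first reading at this position, and it shows no difference beyond the scatter. The entering group brings 2 hydrogen-bond acceptors and 10 heavy atoms where the leaving group has 0 acceptors and 7 heavy atoms, yet this single pair gives no sign that the read-out responds to the exchange. Nothing available explains this result.

From the compounds shown here alone, whether a non-aromatic group at this place, such as a morpholine or a short chain ending in a carboxylic acid, would separate from compound 2 remains open. Also open, going by these compounds, is whether the same exchange on the 2-fluorophenyl group still present in compound 3 would leave the value within the scatter.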